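Bromo for chloro on the shared core of compound 2

The compounds below may be only part of what the source reports. "The series", "measured", "known", "first", "only" and "open" are said of these compounds alone.

Compound 2 `COc1cc(C(=O)O)ccc1Cc1cn(C(c2ccccc2)c2ccccc2)c2ccc(Cl)cc12` stands at the lower end of the two numbers seen so far. In an in vivo ADME assay on the whole organism for pharmacokinetics, with Rattus norvegicus as the target (on this read-out lower numbers stand for lower oral bioavailability and higher numbers for higher oral bioavailability), compound 2 gives 22%. Going by the values given here, the only other measured compound, compound 1 `COc1cc(C(=O)O)ccc1Cc1cn(C(c2ccccc2)c2ccccc2)c2cc(Cl)ccc12`, gives 63% in this assay, a number that lies beyond the usual scatter above that of compound 2, though no single-point step between these two has been worked out.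

Compound 3 `COc1cc(C(=O)O)ccc1Cc1cn(C(c2ccccc2)c2ccccc2)c2ccc(Br)cc12` differs from compound 2 by bromo in place of chloro on an aromatic carbon. Among the compounds with values here, no measured pair shows this swap, so its effect cannot be read from any recorded step. Exchanging one halogen for another halogen is expected to shift the read-out only slightly, if at all beyond the scatter. The step of a number 3 percentage points higher from compound 2 to compound 3 (within the scatter) is therefore expected to be small. Compound 3 is estimated at 25%, with a range from 10% to 45%.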

Compound 3, oral bioavailability: 16%
Estimate against measurement, compound 3: 9 percentage points above; measured number inside the range.
By their numbers in this assay, from the lowest: compounds 3 and 2 (each within the scatter of the next); then compound 1.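

Bromo in place of chloro on this aromatic carbon, meta to a fused ring and para to a fused ring, gives a number 6 percentage points lower from compound 2 to compound 3 (within the scatter) in this assay. Going by these compounds alone, this is the first step recorded at this position, and it shows that exchanging these two halogens here does not separate the compounds on this read-out. No measurement at hand bears on what lies behind this result.

The compounds shown leave open whether fluoro, or a group of another kind such as an amine, would also stay within the scatter at this position. They also leave open whether the same exchange of halogens on compound 1, where the chloro sits at a different place on the shared core, would give a similar step.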